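Extending a Methoxy Side Chain to Ethoxy: Solubility Expectation

The compounds below may be only part of what the source reports. "The series", "measured", "known", "first", "only" and "open" are said of these compounds alone.

Of the compounds shown here, two sharing one core have been measured so far. Compound 1 `CC[n+]1ccc(CCC(=O)c2cc3cc(OC)c(OC)cc3s2)cc1` carries a plain ethyl chain on its charged ring nitrogen, and compound 2 `COCC[n+]1ccc(CCC(=O)c2cc3cc(OC)c(OC)cc3s2)cc1` carries the same chain with a methoxy group on it. In a physicochemical assay for solubility (on this read-out higher numbers stand for higher solubility and lower numbers for lower solubility), compound 1 gives 25000 ug/mL, while in this assay compound 2 gives 33000 ug/mL. Going by the values given here, the single step so far, a 1.3-fold higher number from compound 1 to compound 2 (0.12 log units; within the scatter), arose from placing methoxy in place of hydrogen on a saturated chain carbon, two bonds along the chain from an aromatic nitrogen, and the two numbers lie within the scatter of each other.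

Compound 3 `CCOCC[n+]1ccc(CCC(=O)c2cc3cc(OC)c(OC)cc3s2)cc1` goes one carbon further: methyl in place of hydrogen on a saturated chain carbon bound to an oxygen on a saturated carbon, so the methoxy group becomes an ethoxy group. Among the compounds with values here, only the step from compound 1 to compound 2 bears on this change, and it stayed within the scatter, so no movement beyond the scatter is expected here either. The expected step, a 1.1-fold lower number from compound 2 to compound 3 (0.04 log units; within the scatter), is small. Compound 3 is therefore estimated to give 30000 ug/mL in this assay, with a range from 15000 ug/mL to 60000 ug/mL.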

Compound 3, solubility: 50000 ug/mL
For compound 3 the middle estimate is 1.7-fold (0.22 log units) below the measured one; the measured number falls inside the stated range.
By their numbers in this assay, from the lowest: compounds 1, 2 and 3 (each within the scatter of the next).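

Replacing hydrogen with methyl on a saturated chain carbon bound to an oxygen on a saturated carbon turns methoxy into ethoxy, and in this assay this gives a step that stays within the scatter (a 1.5-fold higher number from compound 2 to compound 3 (0.18 log units; within the scatter)), so this second change to the side chain, like the first, shows no clear movement. The new information is the comparison of the plain ethyl chain with the ethoxy chain: even with the whole ethoxy group in place of hydrogen, two bonds along the chain from an aromatic nitrogen, the step remains printed as within the scatter (a 2.0-fold higher number from compound 1 to compound 3 (0.30 log units; within the scatter)), so the three chains cannot be told apart on this read-out. Nothing on hand offers an explanation for these small differences.

The compounds shown leave open whether any group at this position can move the number beyond the scatter, as all three chains end in ethyl, methoxy or ethoxy. A longer chain such as propoxy, an amine or a carboxylic acid on the same chain would be a different kind of test, and these three compounds do not predict the outcome.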